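Switching the Amide Substituent of Compound 1

The source may report more compounds than this note shows. Statements on the series, on what has been measured and on what is new or still open speak of the compounds shown alone.

Compound 1 `COc1ccc2c(=O)c(/C=C/C(=O)Nc3cccc(C)c3)coc2c1` is the starting point. In a functional assay on HeLa cells (Homo sapiens) for inhibition, read by MTT assay, with a stated time of 48 h (a lower number here means a stronger inhibitor, a higher number a weaker inhibitor), compound 1 gives a limit of the assay rather than a number, > 100000 nM. Compound 2 `COc1ccc2c(=O)c(/C=C/C(=O)NCc3ccc(F)cc3)coc2c1` likewise reaches only a limit in this assay, > 100000 nM. The step that the two limits leave unreadable from compound 1 to compound 2 therefore cannot be read. Compound 3 `COc1ccc(CNC(=O)/C=C/c2coc3cc(OC)ccc3c2=O)cc1` carries 4-methoxybenzyl in place of 3-methylphenyl on an amide-type nitrogen. For the measured compounds named here, the one measured step that bears on it, a step that the two limits leave unreadable from compound 1 to compound 2, stays unreadable, both values sitting at the limit of > 100000 nM in this assay, at which 2 of the 2 values shown sit. No step beyond the scatter can be foreseen, and compound 3 is expected to remain at a limit, so the estimated step is a step that the limit leaves unreadable from compound 1 to compound 3. Compound 3 is thus estimated at 200000 nM, within 50000 nM to 1000000 nM.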

Compound 3, half-maximal inhibitory concentration: > 100000 nM
Compound 3: only a limit was reported (the forecaster's own chance of this, stated with the estimate: 85%); the middle value is on the limit's open side.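

Compound 1, compound 2 and compound 3 all stop at a limit, so no step among them can be read: the limit of > 100000 nM in this assay, at which 3 of the 3 values shown sit.

The compounds shown leave open whether any amide substituent on this core gives a measurable value in this assay.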